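This account rests on a few compounds, and the source may have more. Where it says the series, first, only, none or still open, it means among the compounds named here.

Values in an ADME assay on microsomes from liver (Homo sapiens) for metabolic stability (on this read-out higher numbers stand for fast clearance and lower numbers for slow clearance), for the compounds measured so far

- compound 1 `CCNC1=NS(=O)(=O)c2ccccc21` gives < 3 mL.min-1.g-1 as a limit
- compound 2 `N=S1(=O)c2ccccc2C(=O)N1Cc1ccccc1` gives 19.2 mL.min-1.g-1 as a number
- compound 3 `NC1=NS(=O)(=O)c2ccccc21` gives < 3 mL.min-1.g-1 as a limit

Compound 3 is the starting point, and it gives only a limit, < 3 mL.min-1.g-1, with no number. Going by these compounds, compound 3 sits with one other compound at the limit of < 3 mL.min-1.g-1 in this assay, at which 2 of the 3 values shown sit, so its true position on the scale stays open. The change to compound 4 `O=S1(=O)N=C(Nc2ccccc2)c2ccccc21` is phenyl in place of hydrogen on an amine nitrogen, which places a phenyl on an amine nitrogen where compound 3 carries hydrogen.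

Among the compounds with values here, the one measured step at this nitrogen is a step that the two limits leave unreadable from compound 1 to compound 3, and it offers no size to carry over. It also concerns ethyl rather than phenyl. Within the data shown here, the only number is that of compound 2 at 19.2 mL.min-1.g-1, and compound 2 has a different core arrangement, so it is weak guidance. On that basis a move toward faster clearance in this assay is expected rather than no change, with wide uncertainty, and a further limit remains possible.

The expected step is an at least 2.6-fold higher number from compound 3 to compound 4 (0.42 log units; beyond the scatter) in that direction. For compound 4 the estimate is 8 mL.min-1.g-1, with an expected range from 3 mL.min-1.g-1 to 25 mL.min-1.g-1 for the measurement.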

Compound 4, intrinsic clearance in microsomes: 85.4 mL.min-1.g-1
For compound 4 the middle estimate is 11-fold (1.03 log units) below the measured one, and the stated range ends below it.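

In this assay, this amine nitrogen now gives a readable step: phenyl in place of hydrogen produces an at least 28-fold higher number from compound 3 to compound 4 (1.45 log units; beyond the scatter), and phenyl in place of ethyl at the same nitrogen produces an at least 28-fold higher number from compound 1 to compound 4 (1.45 log units; beyond the scatter). The position therefore tolerates no free exchange of groups on this read-out, since hydrogen and ethyl both leave the compound at a limit with no number, while phenyl moves it well clear of that limit on the same core. Both steps are minimum sizes, and their true sizes stay open: the limit of < 3 mL.min-1.g-1 in this assay, at which 2 of the 4 values shown sit.

The compounds shown leave open whether the rise is tied to phenyl itself or would also appear with a saturated ring such as cyclohexyl, a benzyl group, a longer chain such as butyl, or a fluorophenyl group on the same nitrogen. They also leave open whether the step from hydrogen or ethyl to phenyl would keep its size with a change elsewhere on the shared core.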